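Nitro for Hydrogen Across Two Related Cores

The source may hold more compounds than are shown below. What is called first, only, known or untested is meant among the compounds shown, and "the series" means these compounds.

Compound 1 `N=C(N)c1cccc(OCc2ccccc2)c1`: 156000000 nM in an ADME assay on L6 cells (Rattus norvegicus) for cytotoxicity, read by resazurin assay, with a stated time of 72 h; on this read-out lower numbers stand for stronger inhibition and higher numbers for weaker inhibition
Compound 2 `N=C(N)c1cccc(OCc2cccc([N+](=O)[O-])c2)c1`: 78900000 nM in this assay
Compound 3 `N=C(N)c1ccc(COc2ccccc2)cc1`: 167000000 nM in this assay

Of the compounds shown here, three have been measured so far. Compound 3 and compound 1 have the same atoms joined differently; how the two cores differ is not broken down here. Between compound 1 and compound 3 the values lie within the scatter of each other, so they are read as alike. Compound 2 carries one change relative to compound 1, (nitro in place of hydrogen on an aromatic carbon), and that change gave a 2.0-fold lower number from compound 1 to compound 2 (0.30 log units; within the scatter).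

Compound 4 `N=C(N)c1ccc(COc2cccc([N+](=O)[O-])c2)cc1` has not yet been measured in this assay. It differs from compound 3 by nitro in place of hydrogen on an aromatic carbon, the same change as that from compound 1 to compound 2, made on the other core. Because the earlier step was a 2.0-fold lower number from compound 1 to compound 2 (0.30 log units; within the scatter), the step from compound 3 to compound 4 is expected to be of similar size, a 2.0-fold lower number from compound 3 to compound 4 (0.30 log units; within the scatter). On that basis compound 4 is estimated at 84000000 nM, with a likely range from 40000000 nM to 175000000 nM.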

Compound 4, half-maximal inhibitory concentration: 57800000 nM
Compound 4: the middle estimate sits 1.5-fold (0.16 log units) above what was measured; the measured number falls inside the stated range.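

On the second core, nitro in place of hydrogen on an aromatic carbon gave a 2.9-fold lower number from compound 3 to compound 4 (0.46 log units; beyond the scatter) in this assay and this modest step is the only one of the two that lies beyond the scatter. Set side by side, the two steps run the same way and cannot be told apart in size: the same change on two cores in this assay, a 2.0-fold lower number (0.30 log units; within the scatter) from compound 1 to compound 2 and a 2.9-fold lower number (0.46 log units; beyond the scatter) from compound 3 to compound 4, 1.5-fold (0.16 log units) apart, within the scatter of two such steps. Across these two cores the change therefore carries over as far as this read-out can tell, but two pairs do not show that it would hold on any further core, and they give no reason why the number is lower with nitro present.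

The compounds shown leave open whether another group in place of that hydrogen, such as an amine or a carboxylic acid, would give a step of like size on either core. They also leave open whether a group of that kind would behave alike on both cores, as nitro does here.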